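This account rests on a few compounds, and the source may have more. Where it says the series, first, only, none or still open, it means among the compounds named here.

Measured so far in an ADME assay on MDCK cells (Canis lupus familiaris) for cytotoxicity; on this read-out lower numbers stand for higher toxicity in this test and higher numbers for lower toxicity in this test:
Compound 1 `CC1(C)C[C@H](O)C[C@](C)(CNC(=O)c2cc(Cl)ccc2O)C1` gives > 50000 nM, which is a limit of the assay and not a number.
Compound 2 `O=C(N1CCOCC1)C1(c2ccccc2)CCCC1` gives > 100000 nM, again a limit rather than a number.
Compound 3 `O=C(Nc1ccccc1)C1(c2ccccc2)CCCC1` gives > 100000 nM, also a limit.

Compound 3 thus has no measured number in this assay, only a limit; it sits at the limit of > 100000 nM in this assay, at which 2 of the 3 values shown sit. Compound 1 sits at the limit of > 50000 nM in this assay, at which 1 of the 3 values shown sits. For the measured compounds named here, none of the three compounds shows measurable toxicity within the tested range, and no pair of them differs in a single place, so no measured step is available.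

Compound 4 `CCN(C(=O)C1(c2ccccc2)CCCC1)c1ccccc1` has not yet been measured. It differs from compound 3 by ethyl in place of hydrogen on an amide-type nitrogen. Since compound 3 already stands at a limit and the change only adds an ethyl group on the amide nitrogen, the step from compound 3 to compound 4 is expected to be a number no higher from compound 3 to compound 4 (the limit leaves the size open), that is, nothing beyond the usual scatter in either direction. Compound 4 is therefore estimated at 100000 nM, with a range from 30000 nM to 300000 nM, and is most likely to be reported again as a limit.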

Compound 4, half-maximal cytotoxic concentration: 56000 nM
Compound 4: middle estimate off by 1.8-fold (0.25 log units), on the high side; measured number inside the range.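

In this assay, ethyl in place of hydrogen on an amide-type nitrogen gives an at least 1.7-fold lower number from compound 3 to compound 4 (0.25 log units; that floor lies within the scatter). Compound 4 is the first compound shown with a real number instead of a limit, so this position is the first place where a single change can be followed into the range this test can read. The true size of the step remains unknown, and it may be much larger than its floor, since compound 3 has only a limit: the limit of > 100000 nM in this assay, at which 2 of the 4 values shown sit.

The compounds shown leave open whether the read-out follows chain length on this nitrogen, as neither a methyl group nor a longer chain such as butyl appears among them. As far as these compounds go, it is also open how a chain ending in an amine at the same place would read in this assay.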